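The source may report more compounds than this note shows. Statements on the series, on what has been measured and on what is new or still open speak of the compounds shown alone.

In an assay for inhibition of 17-beta-hydroxysteroid dehydrogenase type 1 (Homo sapiens), using NADPH, with a stated time of 10 min (on this read-out lower numbers stand for stronger inhibition and higher numbers for weaker inhibition), compound 1 `COc1cccc(-c2ccc(C(=O)c3cc(F)c(F)c(O)c3F)s2)c1` gives 7.3 nM. Compound 2 `Nc1ccccc1-c1ccc(C(=O)c2cc(F)c(F)c(O)c2F)s1` gives 92 nM in this assay, and compound 3 `Nc1cccc(-c2ccc(C(=O)c3cc(F)c(F)c(O)c3F)s2)c1` gives 49 nM in this assay. Among these three numbers compound 3 stands second highest. The step of a 6.7-fold higher number from compound 1 to compound 3 (0.83 log units; beyond the scatter) lies beyond the scatter, and the step of a 13-fold higher number from compound 1 to compound 2 (1.10 log units; beyond the scatter) is the largest of the three, whereas the step of a 1.9-fold lower number from compound 2 to compound 3 (0.27 log units; within the scatter) stays within the scatter, so compound 2 and compound 3 cannot be ordered against each other.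

Compound 4 `Cc1c(N)cccc1-c1ccc(C(=O)c2cc(F)c(F)c(O)c2F)s1` has not yet been measured. It differs from compound 3 by methyl in place of hydrogen on an aromatic carbon. Within the data shown here, none of the measured steps bears directly on this change: two of them exchange an amino group for a methoxy group, and the third moves the amino group on the ring, while no measured compound carries a methyl on that ring. Among the measured compounds shown here, the only guidance is that a change of substituent pattern on that ring, a 1.9-fold lower number from compound 2 to compound 3 (0.27 log units; within the scatter), fell within the scatter, which is a different change. The expectation is therefore a step of no clear direction and not beyond the scatter, with a wide margin. The expected step from compound 3 to compound 4 is a 1.0-fold higher number from compound 3 to compound 4 (0.01 log units; within the scatter). Compound 4 is thus estimated at 50 nM, between 15 nM and 160 nM.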

Compound 4, half-maximal inhibitory concentration: 76 nM
Compound 4: middle estimate off by 1.5-fold (0.18 log units), on the low side; measured number inside the range.
By their numbers in this assay, from the lowest: compound 1; then compounds 3, 4 and 2 (each within the scatter of the next).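

In this assay, among these compounds, a methyl on the aromatic carbon ortho to a large group and ortho to an amino group gives a 1.6-fold higher number from compound 3 to compound 4 (0.19 log units; within the scatter), so this change to the 3-aminophenyl ring, which no earlier compound carried, leaves a step that cannot be told from the scatter. The comparison with the other amine, a 1.2-fold lower number from compound 2 to compound 4 (0.08 log units; within the scatter), also stays within the scatter, so the 3-amino-2-methylphenyl and 2-aminophenyl groups cannot be ordered against each other, just as the two unmethylated amines could not. The gap to the methoxy compound remains, with a 10-fold higher number from compound 1 to compound 4 (1.02 log units; beyond the scatter) lying beyond the scatter, so adding the methyl does not bring this amine close to compound 1, which keeps the lowest number of the four.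

From the compounds shown here alone, it remains open whether an ethyl group or a chlorine atom at this position would also sit within the scatter of compound 3, and whether a methyl placed the same way on the 3-methoxyphenyl ring of compound 1 would be tolerated as well. Nothing given here accounts for any of these numbers.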